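The source may report more compounds than this note shows. Statements on the series, on what has been measured and on what is new or still open speak of the compounds shown alone.

Compound 3 `COc1ccc(NC(=O)Nc2ccc(Nc3ncnc4c3OCCN4)cc2)cc1` gives 824 nM in an assay on isolated protein for inhibition of proto-oncogene tyrosine-protein kinase receptor Ret variant V804M (Homo sapiens), read by 33P incorporation, with stated times of 15 min and 40 min (a lower number here means a stronger inhibitor, a higher number a weaker inhibitor), which places it second highest of the three numbers shown. Its nearest neighbour is compound 1 `O=C(Nc1ccc(Br)cc1)Nc1ccc(Nc2ncnc3c2OCCN3)cc1`, which gives 2350 nM in this assay; the furthest is compound 2 `O=C(Nc1ccc(Nc2ncnc3c2OCCN3)cc1)Nc1ccc(C(F)(F)F)cc1`, which gives 276 nM. The measured steps all change one substituent on the terminal ring: a 2.9-fold lower number from compound 1 to compound 3 (0.46 log units; beyond the scatter), an 8.5-fold lower number from compound 1 to compound 2 (0.93 log units; beyond the scatter) and a 3.0-fold higher number from compound 2 to compound 3 (0.48 log units; beyond the scatter). Each is modest, none within the scatter, and together they show that swapping a single group on that ring moves the number modestly in either direction.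

Compound 4 `Cc1ccc(F)c(NC(=O)Nc2ccc(Nc3ncnc4c3OCCN4)cc2)c1` is not yet measured. It differs from compound 3 by 2-fluoro-5-methylphenyl in place of 4-methoxyphenyl on an amide-type nitrogen. Among the compounds with values here, no measured step covers this particular swap, so the direction cannot be read from the data; the measured steps only set its likely size. The step from compound 3 to compound 4 is therefore expected to be modest, a 1.4-fold lower number from compound 3 to compound 4 (0.14 log units; within the scatter). Compound 4 is estimated at 600 nM in this assay, within a range from 150 nM to 2400 nM.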

Compound 4, half-maximal inhibitory concentration: 5110 nM
The estimate for compound 4 lay 8.5-fold (0.93 log units) below the measured number; measured number outside the range, above it.
By their numbers in this assay, from the lowest: compound 2; then compound 3; then compound 1; then compound 4.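

In this assay, within the data shown here, the swap to 2-fluoro-5-methylphenyl on the amide-type nitrogen gives the highest number of the four compounds, with a 6.2-fold higher number from compound 3 to compound 4 (0.79 log units; beyond the scatter) and a 2.2-fold higher number from compound 1 to compound 4 (0.34 log units; beyond the scatter) and, as the only large step here, a 19-fold higher number from compound 2 to compound 4 (1.27 log units; beyond the scatter) in this series. The 4-bromophenyl, 4-methoxyphenyl and 4-(trifluoromethyl)phenyl compounds had shown only modest steps among themselves, so this result shows that a change at this position can move the number further than those three suggested. Nothing available explains why this group gives the weakest inhibitor of the four.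

The compounds shown leave open whether the fluoro or the methyl group accounts for the rise, since neither appears alone on the terminal ring. They also leave open how an amine or a carboxylic acid on that ring would behave.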